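The source may hold more compounds than are shown below. What is called first, only, known or untested is meant among the compounds shown, and "the series" means these compounds.

Compound 1 `O=C(COc1ccc2cc(C(O)(C(F)(F)F)C(F)(F)F)c(O)cc2c1)Nc1nc2ccccc2s1`: 9900 nM in an assay on isolated protein for inhibition of tyrosine-protein phosphatase non-receptor type 13 (Homo sapiens), read by spectrophotometry; a higher number here means a weaker inhibitor, a lower number a stronger inhibitor
Compound 2 `O=C(COc1ccc2cc(C(O)(C(F)(F)F)C(F)(F)F)c(O)cc2c1)NCc1ccccc1`: > 20000 nM in this assay, a limit of the assay and not a number

Compound 2 therefore stands at the limit of > 20000 nM in this assay, at which 1 of the 2 values shown sits, reached by the step of an at least 2.0-fold higher number from compound 1 to compound 2 (0.30 log units; that floor lies within the scatter). Compound 3 `O=C(COc1ccc2cc(C(O)(C(F)(F)F)C(F)(F)F)c(O)cc2c1)NCc1ccc(F)cc1` differs from compound 2 by fluoro in place of hydrogen on an aromatic carbon, the same difference read one bond further out as benzyl to 4-fluorobenzyl. Going by the values given here, no measured step touches that change; the only measured step concerns the group on the amide-type nitrogen. Compound 2 already sits at the limit of > 20000 nM in this assay, at which 1 of the 2 values shown sits, and the step that the limit leaves unreadable from compound 2 to compound 3 is expected to remain within the scatter. Compound 3 is estimated at 25000 nM, between 10000 nM and 60000 nM, most likely reported again only as a limit.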

Compound 3, half-maximal inhibitory concentration: > 20000 nM
Compound 3 ended at the assay's limit (the forecaster's own chance of this, stated with the estimate: 75%); the middle value does not contradict the limit.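

With 4-fluorobenzyl on the amide-type nitrogen, compound 3 joins compound 2 at the top of the readable range: the limit of > 20000 nM in this assay, at which 2 of the 3 values shown sit. Replacing the 1,3-benzothiazol-2-yl group of compound 1 with 4-fluorobenzyl gives an at least 2.0-fold higher number from compound 1 to compound 3 (0.30 log units; that floor lies within the scatter), so this floor alone does not establish a loss. The step from hydrogen to fluoro cannot be read, as compound 2 and compound 3 both stand at limits. Still open, going by these compounds, is whether fluoro has any readable effect on a compound with a measured value, such as compound 1. Also open, on these data alone, is whether an amine or a carboxylic acid on the benzyl ring would give a value in this assay rather than a limit.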